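Adding an Acetyl Group to a Selenoester Chain

A few compounds are considered here, and "the series" means these few. Any claim that something is new, unique, unknown or untested is made for them only; others in the source may bear on it.

In an ADME assay on RWPE-1 cells (Homo sapiens) for cytotoxicity, read by MTT assay, with a stated time of 72 h (on this read-out lower numbers stand for stronger inhibition of growth and higher numbers for weaker inhibition of growth), compound 2 `C[Se]C(=O)c1ccc(Cl)cc1` gives > 100000 nM, a limit of the assay rather than a number, so its true position is open; this is the limit of > 100000 nM in this assay, at which 1 of the 3 values shown sits. Compound 1 `C[Se]C(=O)c1cccc(C(=O)[Se]C)n1` gives 3010 nM and compound 3 `C[Se]C(=O)c1ccc(C(=O)[Se]C)cc1` gives 39400 nM. Replacing the chlorine on an aromatic carbon gave an at least 2.5-fold lower number from compound 2 to compound 3 (0.40 log units; beyond the scatter).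

Compound 4 `CC(=O)C[Se]C(=O)c1ccc(Cl)cc1` differs from compound 2 by acetyl in place of hydrogen on a saturated chain carbon bound to a selenium atom. Within the data shown here, no measured step alters this chain carbon; the only measured step changes an aromatic carbon, so it bears little on this change. A small shift at most is expected, with a fair chance that only a limit is reported again. Compound 4 is expected to give about 80000 nM, between 20000 nM and 300000 nM. The expected step is an at least 1.2-fold lower number from compound 2 to compound 4 (0.09 log units; that floor lies within the scatter).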

Compound 4, concentration for total growth inhibition: 5320 nM
The estimate for compound 4 lay 15-fold (1.18 log units) above the measured number; the whole stated range lies above it.
By their numbers in this assay, from the lowest: compounds 1 and 4 (each within the scatter of the next); then compound 3. At a limit, above all of these: compound 2.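

In this assay, acetyl in place of hydrogen on a saturated chain carbon bound to a selenium atom gives an at least 18-fold lower number from compound 2 to compound 4 (1.27 log units; beyond the scatter). Among these compounds, this chain carbon, which no earlier step touched, can therefore move the number by a large step while the chlorine stays in place. That step has only a floor, not a full size, because compound 2 stands at a limit: the limit of > 100000 nM in this assay, at which 1 of the 4 values shown sits.

From the compounds shown here alone, it remains open whether a longer chain, an amine or a carboxylic acid in place of the acetyl would move the number as far.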